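The source may hold more compounds than are shown below. What is called first, only, known or untested is meant among the compounds shown, and "the series" means these compounds.

Compound 3 `Cc1ccc(C(=O)OC2CCC(CN3CCN(c4cc(=O)c5cc(C(F)(F)F)cc([N+](=O)[O-])c5s4)CC3)CC2)cc1` was examined in an ADME assay on cells (Hepatocyte, Mus musculus) for metabolic stability (on this read-out lower numbers stand for a shorter-lived compound and higher numbers for a longer-lived compound), where compound 3 gives 0.202 h. Its close relative compound 2 `COc1ccc(C(=O)OC2CCC(CN3CCN(c4cc(=O)c5cc(C(F)(F)F)cc([N+](=O)[O-])c5s4)CC3)CC2)cc1` gives 0.295 h in this assay, and the step of a 1.5-fold lower number from compound 2 to compound 3 (0.16 log units; within the scatter) does not separate the two. Compound 1 `CC(=O)NC1CCC(CN2CCN(c3cc(=O)c4cc(C(F)(F)F)cc([N+](=O)[O-])c4s3)CC2)CC1`, by contrast, reaches only a limit of this assay: compound 1 gives > 1.55 h. That limit, (the limit of > 1.55 h in this assay, at which 1 of the 3 values shown sits), underlies the steps of an at least 5.2-fold lower number from compound 1 to compound 2 (0.72 log units; beyond the scatter) and an at least 7.6-fold lower number from compound 1 to compound 3 (0.88 log units; beyond the scatter), both of which exchange acetamido for an aroyloxy group on a saturated ring carbon. So among the numbers shown, compound 3 and compound 2 sit within the scatter of each other, while compound 1 stands apart as a limit.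

Compound 4 `CC(=O)OC1CCC(CN2CCN(c3cc(=O)c4cc(C(F)(F)F)cc([N+](=O)[O-])c4s3)CC2)CC1` carries the change (methyl in place of 4-methylphenyl on a carbonyl carbon). Among the measured compounds shown here, the steps that bear on it are those from compound 1: a small acetamido group went with the longest-lived reading, and both aroyloxy groups went with markedly shorter half-lives, whereas the methyl-for-methoxy swap between compound 2 and compound 3 stayed within the scatter. Paring the ester down to acetoxy is therefore expected to move compound 4 back upward, by an estimated 2.5-fold higher number from compound 3 to compound 4 (0.39 log units; beyond the scatter). Compound 4 is expected to give 0.5 h, within a range from 0.2 h to 1.5 h.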

Compound 4, half-life: < 0.15 h
Compound 4 gave a limit, no number; the forecaster's own chance of this, stated with the estimate: 15%; middle value at least 3.3-fold (0.52 log units) from the limit.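

Paring the ester down to acetoxy did not bring back a long half-life in this assay, and compound 4 gives a limit of this read-out rather than a number: the limit of < 0.15 h in this assay, at which 1 of the 4 values shown sits. The exchange of acetamido for acetoxy on a saturated ring carbon gives an at least 10-fold lower number from compound 1 to compound 4 (1.01 log units; beyond the scatter), so with the acetyl group kept in both compounds, a small group alone does not go with the long-lived reading, and none of the three esters shown goes against this split from the amide. Against the two larger esters the steps are an at least 1.3-fold lower number from compound 3 to compound 4 (0.12 log units; that floor lies within the scatter) and an at least 1.9-fold lower number from compound 2 to compound 4 (0.29 log units; that floor lies within the scatter), and since both floors lie within the scatter, replacing the aromatic ring of the ester with methyl is not shown to change the reading in either direction.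

The compounds shown leave open whether an aryl amide such as 4-methylbenzamido on the same saturated ring carbon would read with compound 1 or with the esters, which would separate the effect of the link from that of the acyl group. As far as these compounds go, it also remains open how a plain hydroxyl or a methoxy group in that place would read in this assay.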